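The source may hold more compounds than are shown below. What is called first, only, known or untested is meant among the compounds shown, and "the series" means these compounds.

Two amides on the shared core have numbers in a functional assay on CHO-K1 cells for antagonist activity at transient receptor potential cation channel subfamily V member 1 (Homo sapiens), read by FLIPR; a higher number here means a weaker inhibitor, a lower number a stronger inhibitor. Compound 1 `CCCCNc1nc(C(F)(F)F)ccc1CNC(=O)C(C)c1ccc(NS(C)(=O)=O)c(F)c1` gives 9.1 nM in this assay. Among the measured compounds shown here, compound 2 `CC(C(=O)NCc1ccc(C(F)(F)F)nc1NCc1ccc(Cl)cc1)c1ccc(NS(C)(=O)=O)c(F)c1` gives 65.7 nM in this assay, the higher of the two numbers, the only measured step being a 7.2-fold higher number from compound 1 to compound 2 (0.86 log units; beyond the scatter). Compound 3 `CC(C(=O)NCc1ccc(C(F)(F)F)nc1N(C)c1ccccc1)c1ccc(NS(C)(=O)=O)c(F)c1` differs from compound 2 by methyl(phenyl)amino in place of (4-chlorobenzyl)amino on an aromatic carbon. For the measured compounds named here, no measured step covers this change; the one step at hand only shows an aryl group on that nitrogen sitting above propyl. Compound 3 is therefore expected to change by a 1.5-fold higher number from compound 2 to compound 3 (0.18 log units; within the scatter), the estimate being 100 nM with a range of 25 nM to 400 nM.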

Compound 3, inhibition constant: 0.9 nM
Compound 3: middle estimate off by 110-fold (2.05 log units), on the high side; the whole stated range lies above it.
By their numbers in this assay, from the lowest: compound 3; then compound 1; then compound 2.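

Methyl(phenyl)amino on this aromatic carbon gives a 73-fold lower number from compound 2 to compound 3 (1.86 log units; beyond the scatter) and a 10-fold lower number from compound 1 to compound 3 (1.00 log units; beyond the scatter) in this assay, so a ring-bearing group here does not by itself raise the number, as the single earlier step suggested. The entering group has 0 hydrogen-bond donors against 1 in (4-chlorobenzyl)amino, and its phenyl ring also sits directly on the nitrogen. No available evidence accounts for the size of this step.

On these data alone, whether the methyl or the directly attached phenyl carries the change remains open. Phenylamino and methyl(benzyl)amino on this carbon would separate the two.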